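Swapping isobutylamino for hydroxy on a saturated ring carbon

The compounds below may be only part of what the source reports. "The series", "measured", "known", "first", "only" and "open" are said of these compounds alone.

Within the data shown here, in a functional assay on HT-22 cells (Mus musculus), read by LDH release (on this read-out lower numbers stand for higher toxicity in this test and higher numbers for lower toxicity in this test), compound 1 `CC(C)CNC1Oc2ccc(C(=O)c3ccccc3)c(O)c2NC1(C)C` gives 160 uM as the only true number so far. Compound 2 `CN(CC1OCCO1)C1Oc2ccc(C(=O)c3ccccc3)c(O)c2NC1c1ccccc1` shows > 250 uM as a limit of the assay. Compound 3 `COC(CNC1Oc2ccc(C(=O)c3ccccc3)c(O)c2NC1c1ccccc1)OC` likewise shows > 250 uM as a limit. Compound 4 `CC1(C)Nc2c(ccc(C(=O)c3ccccc3)c2O)OC1O` has not been measured yet. The change hydroxy in place of isobutylamino on a saturated ring carbon puts hydroxy in place of isobutylamino on a saturated ring carbon, next to the ring oxygen. Among the measured compounds shown here, the one measured step that the two limits leave unreadable from compound 2 to compound 3 also falls on a saturated ring carbon but has no readable size to carry over. With no readable guide, the expected move is a 1.3-fold higher number from compound 1 to compound 4 (0.10 log units; within the scatter) and nothing beyond the usual scatter in either direction. For compound 4 the expected value is 200 uM with an estimated span from 80 uM to 450 uM as the likely range.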

Compound 4, half-maximal toxic concentration: > 250 uM
Compound 4 ended at the assay's limit; the forecaster's own chance of this, stated with the estimate: 35%; middle value at least 1.2-fold (0.09 log units) from the limit.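

Unlike the earlier step between compound 2 and compound 3, which the two limits leave unreadable, this change gives a step that can be read at this saturated ring carbon: an at least 1.5-fold higher number from compound 1 to compound 4 (0.19 log units; that floor lies within the scatter). Hydroxy can therefore replace isobutylamino in this assay without any sign of a lower number, although the step's floor is too small to prove a real difference. Its full size stays hidden because the reading for compound 4 is a limit: the limit of > 250 uM in this assay, at which 3 of the 4 values shown sit.

On these data alone, how a simple amine, a carboxylic acid or a longer chain would read on this carbon remains open.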